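Trading the methylaminophenyl for a tolyl ring

The source may hold more compounds than are shown below. What is called first, only, known or untested is meant among the compounds shown, and "the series" means these compounds.

Compound 1 `CC[C@@H](Nc1c(C#N)c(-c2ccc(-c3ccccc3NC)cc2)nc2cnccc12)C(N)=O` gives 2.5 in a physicochemical assay for lipophilicity, read by HPLC, at pH 7.5 (on this read-out lower numbers stand for lower lipophilicity and higher numbers for higher lipophilicity), the second highest of the three numbers measured: compound 3 `CCOc1ccccc1-c1ccc(-c2nc3cnccc3c(NC(C)C(=O)O)c2C#N)cc1` gives 2.1, and compound 2 `CCOc1ccccc1-c1ccc(-c2nc3cnccc3c(N[C@H](CC(C)C)C(N)=O)c2C#N)cc1` gives 3.4. Compound 4 `CC[C@@H](Nc1c(C#N)c(-c2ccc(-c3cccc(C)c3)cc2)nc2cnccc12)C(N)=O` differs from compound 1 in one place: 3-methylphenyl in place of 2-(methylamino)phenyl on an aromatic carbon. Within the data shown here, the single measured step, a number 1.30 log units lower from compound 2 to compound 3 (beyond the scatter), concerns an exchange on the amine nitrogen rather than on the aryl ring, so no measured step bears directly on this change; it shows only how far one exchange can move this assay. The group that leaves counts one hydrogen-bond donor and one acceptor, the group that enters none, and compound 4 is expected to come out modestly higher, a step of a number 0.50 log units higher from compound 1 to compound 4 (beyond the scatter). The estimate for compound 4 is 3, between 2.5 and 3.5.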

Compound 4, distribution coefficient: 3
Compound 4: middle estimate and measured number agree at the digits printed; the range from low to high includes it.
By their numbers in this assay, from the lowest: compound 3; then compound 1; then compound 4; then compound 2.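

Exchanging the group on this aromatic carbon moves the number in this assay (a number 0.50 log units higher from compound 1 to compound 4 (beyond the scatter)), so the aryl ring, and not only the substituent on the amine nitrogen, changes this read-out beyond the scatter. The exchange replaces 2-(methylamino)phenyl with 3-methylphenyl and so alters the substituent, its place on the ring and the hydrogen-bond count together, and the step cannot separate these. Nothing shown explains the step.

As far as these compounds go, how a primary amine or a carboxylic acid on this phenyl ring would read in this assay stays open. Also open, from the compounds shown here alone, is whether the step would hold with the amine-nitrogen substituents of compound 2 and compound 3.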